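The source may report more compounds than this note shows. Statements on the series, on what has been measured and on what is new or still open speak of the compounds shown alone.

Measured so far in an ADME assay for permeability, using PAMPA, at pH 7.4; a higher number here means that the compound crosses the layer faster, a lower number that the compound crosses the layer more slowly:
- compound 1 `O=C(Nc1nc2ccc(Cl)cc2s1)c1cc([N+](=O)[O-])ccc1Cl`: 138 10^-6 cm/s
- compound 2 `Cc1ccc(-c2nc3ccccc3s2)cc1NC(=O)c1cc([N+](=O)[O-])c(N(C)C)cc1Cl`: < 1 10^-6 cm/s
- compound 3 `O=C(Nc1ccc(O)c(-c2nc3ccccc3s2)c1)c1cc([N+](=O)[O-])ccc1Cl`: "below limit of detection" (no number reported)

Compound 2 has no number of its own: < 1 10^-6 cm/s is a limit of the assay and not a measured value. That places compound 2 at the limit of < 1 10^-6 cm/s in this assay, at which 1 of the 3 values shown sits. Compound 3 gives no number either, with the entry "below limit of detection" (no number reported). Among the compounds with values here, compound 1, at 138 10^-6 cm/s, is thus the only one of the three with a true reading, and no measured pair differs in a single place.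

Compound 4 `Cc1ccc(-c2nc3ccccc3s2)cc1NC(=O)c1cc([N+](=O)[O-])c(N2CCCCC2)cc1Cl` changes compound 2 in one place: piperidin-1-yl in place of dimethylamino on an aromatic carbon. Here piperidin-1-yl stands in place of dimethylamino on an aromatic carbon, ortho to a nitro group and meta to a chloro group. The rest of the structure stays the same.

Within the data shown here, no measured step shows what this swap does, so the expectation rests on the starting point alone. Compound 4 keeps everything else of compound 2, which reads < 1 10^-6 cm/s, so no change beyond the usual scatter is expected, and another limit in place of a number would be no surprise. The expected move is a step that the limit leaves unreadable from compound 2 to compound 4. For compound 4 the estimated value is 0.8 10^-6 cm/s, with an expected range of 0.2 10^-6 cm/s to 3 10^-6 cm/s.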

Compound 4, apparent permeability: < 1 10^-6 cm/s
Compound 4: only a limit was reported (the forecaster's own chance of this, stated with the estimate: 75%); the middle value is on the limit's open side.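

In this assay compound 4 gives < 1 10^-6 cm/s, a limit of the assay and not a number. Compound 2 gives < 1 10^-6 cm/s, also a limit, so no step can be read between compound 2 and compound 4. The compounds shown leave open whether piperidin-1-yl in place of dimethylamino changes the true reading at all, in either direction.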